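A Hydroxy Group on the Cyclohexyl Ring and Distribution

The compounds below may be only part of what the source reports. "The series", "measured", "known", "first", "only" and "open" are said of these compounds alone.

This account concerns three compounds that share one core and differ only in the saturated ring attached to it. Compound 1 `Cn1nc(-c2ccc(C(N)=O)cc2)s/c1=N\C1CCCC(O)C1` was run twice in an in vivo ADME assay on the whole organism for pharmacokinetics, at a dose of 0.5 mg/kg by the intravenous route (a lower number here means that more of the compound stays in the plasma, a higher number that more of the compound sits outside the plasma), and gave 1.39 L/kg; 1.78 L/kg (2 entries). Within the data shown here, compound 2 `Cn1nc(-c2ccc(C(N)=O)cc2)s/c1=N\C1CCCCC1` gives in this assay a value of 7.65 L/kg, the only number it has there, with one further entry that did not yield a single number. Among the numbers shown, compound 2 stands clearly apart from compound 1, and the gap between them is far wider than the usual scatter of repeated measurements.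

Compound 3 `Cn1nc(-c2ccc(C(N)=O)cc2)s/c1=N\C1CCCCC1O` has not yet been measured in this assay. Its difference from compound 2 is hydroxy in place of hydrogen on a saturated ring carbon. Among the measured compounds shown here, no step between measured compounds is available for this exact change, so the expectation rests on what the numbers show. The writer expects a downward step in this assay of a 3.8-fold lower number from compound 2 to compound 3 (0.58 log units; beyond the scatter), well beyond the scatter, because compound 1, which also carries a hydroxy group on its ring, gives (the several entries of compound 1 in this assay, 1.39 L/kg; 1.78 L/kg (2 entries)). For compound 3 in this assay the estimate is 2 L/kg, within a range from 1 L/kg to 4.5 L/kg.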

Compound 3, volume of distribution: 1.47 L/kg
Compound 3: middle estimate off by 1.4-fold (0.13 log units), on the high side; the measured number falls inside the stated range.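

In this assay, among these compounds, the first step with hydroxy in place of hydrogen on a saturated ring carbon, here next to the ring atom that bears a large group, is large: a 5.2-fold lower number from compound 2 to compound 3 (0.72 log units; beyond the scatter). Among the compounds shown here, it turns the cyclohexyl to 2-hydroxycyclohexyl change into a direct comparison, although the step rests on the one number available for compound 2. For the compounds shown here, the earlier compounds could show only that a compound with a hydroxy group elsewhere on its ring gave a low number, whereas compound 3, at 1.47 L/kg, now shows that a low number also occurs with the hydroxy group at this carbon, and that value sits among the repeated entries for the other hydroxy compound: the several entries of compound 1 in this assay, 1.39 L/kg; 1.78 L/kg (2 entries).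

The compounds shown leave open whether the step belongs to hydroxy itself or would also appear with methoxy, an amine or a carboxylic acid on the same ring carbon. They also leave open how far a hydroxymethyl group, which sets the oxygen one carbon further from the ring, would carry the same low number in this assay.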